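Working notes: swapping phenyl for thiophen-3-yl

The compounds below may be only part of what the source reports. "The series", "measured", "known", "first", "only" and "open" are said of these compounds alone.

compound 1 `Oc1ccccc1-c1cc(-c2ccccc2)cc(-c2ccccc2O)n1` gives 37300 nM
compound 2 `Oc1ccc(-c2cc(-c3ccccc3)cc(-c3cccs3)n2)cc1` gives 2400 nM
compound 3 `Oc1cccc(-c2cc(-c3ccccc3)nc(-c3ccccc3)c2)c1` gives 19500 nM

In a functional assay on MDA-MB-231 cells (Homo sapiens) for cytotoxicity, read by ELISA, with a stated time of 2 days (a lower number here means a stronger inhibitor, a higher number a weaker inhibitor), compound 3 (19500 nM) cannot be told apart from compound 1 (37300 nM), while compound 2 (2400 nM) gives a lower number, beyond the scatter. Compound 4 `Oc1cccc(-c2cc(-c3ccccc3)nc(-c3ccsc3)c2)c1` has thiophen-3-yl in place of phenyl on an aromatic carbon, next to the ring nitrogen (thiophen-3-yl in place of phenyl on an aromatic carbon). Among the compounds with values here, no measured pair isolates this change. Within the data shown here, compound 2 (2400 nM) is the only measured compound with a five-membered aromatic ring, but it differs from compound 3 in more than one place, so it offers limited guidance. A modest move towards a lower number is expected (a 2.2-fold lower number from compound 3 to compound 4 (0.34 log units; beyond the scatter)), though a step within the scatter remains possible. For compound 4 the estimated value is 9000 nM (expected range 3500 nM to 23000 nM).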

Compound 4, half-maximal inhibitory concentration: 19000 nM
Compound 4: middle estimate off by 2.1-fold (0.32 log units), on the low side, and the stated range covers the measured number.
By their numbers in this assay, from the lowest: compound 2; then compounds 4, 3 and 1 (each within the scatter of the next).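

In this assay, within the data shown here, thiophen-3-yl in place of phenyl on the aromatic carbon next to the ring nitrogen gives a 1.0-fold lower number from compound 3 to compound 4 (0.01 log units; within the scatter), the first step that isolates a single place. This position therefore accepts the five-membered aromatic ring with its sulfur, and the swap alone produces no readable shift. No supporting data bear on this result. Still open, on these data alone, is whether an amine or a longer chain at this position would give a step beyond the scatter. Also open, as far as these compounds go, is how a carboxylic acid in place of the hydroxyl of the 3-hydroxyphenyl group would read.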